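Triazole hydroxamates: shortening the phenylpropyl amine substituent

The compounds below may be only part of what the source reports. "The series", "measured", "known", "first", "only" and "open" are said of these compounds alone.

Compound 3 `O=C(NO)c1cccc(-c2cn([C@@H]3C[C@@H](CO)N(CCCc4ccccc4)C3)nn2)c1` carries a phenethyl on a saturated chain carbon bound to an amine nitrogen in a ring; compound 1 `O=C(NO)c1cccc(-c2cn([C@@H]3C[C@@H](CO)N(Cc4ccccc4)C3)nn2)c1` differs from it by phenyl in place of phenethyl on a saturated chain carbon bound to an amine nitrogen in a ring. In an assay on Sf9 cells for inhibition of histone deacetylase 11 (Homo sapiens), read by fluorescence, tested at 0.5 uM (on this read-out higher numbers stand for more inhibition at the one concentration tested (going by the name of the read-out) and lower numbers for less inhibition), compound 3 gives only a limit, < 10%. Compound 1 also gives only a limit in this assay, < 10%. The step that the two limits leave unreadable from compound 3 to compound 1 thus cannot be read, as the limit of < 10% in this assay, at which 3 of the 3 values shown sit, shows. Compound 2 `O=C(NO)c1cccc(-c2cn([C@H]3C[C@H](C(=O)O)N(CCCc4ccccc4)C3)nn2)c1` rests on a core whose difference from the core of compound 3 is not broken down here. In this assay compound 2 gives only a limit, < 10%. Compound 4 `O=C(NO)c1cccc(-c2cn([C@H]3C[C@H](C(=O)O)N(Cc4ccccc4)C3)nn2)c1` is not yet measured and differs from compound 2 by phenyl in place of phenethyl on a saturated chain carbon bound to an amine nitrogen in a ring, the same change at the same place. The expected step that the limit leaves unreadable from compound 2 to compound 4 is small, resting on the unreadable step that the two limits leave unreadable from compound 3 to compound 1 and on (the limit of < 10% in this assay, at which 3 of the 3 values shown sit). Compound 4 is expected to give 5% in this assay, within 0% to 14%, most likely again only a limit.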

Compound 4, a percentage reported as inhibition, at one concentration (the size of the read-out at that concentration, not a potency): < 10%
Compound 4 ended at the assay's limit; the forecaster's own chance of this, stated with the estimate: 85%; the middle value lies beyond the limit too.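

No step can be read from compound 2 to compound 4, as both sit at the assay's limit: the limit of < 10% in this assay, at which 4 of the 4 values shown sit.

The compounds shown leave open whether the change from 3-phenylpropyl to benzyl has any effect in this assay; none gives a value clear of the limit.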